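The compounds below may be only part of what the source reports. "The series", "measured", "known", "first", "only" and "open" are said of these compounds alone.

Among the three compounds measured so far, compound 3 `C/C(C#Cc1ccccc1)=N\N/C(N)=N/S(=O)(=O)c1cc(C)c(Cl)cc1SCc1ccc(C)cc1` gives the highest number: in a functional assay on HeLa cells (Homo sapiens) for antiproliferative activity, read by MTT assay, with a stated time of 72 h (on this read-out lower numbers stand for stronger inhibition and higher numbers for weaker inhibition), compound 3 gives 110000 nM. Compound 1 `Cc1cc(S(=O)(=O)/N=C(\N)N/N=C/C#Cc2ccccc2)c(SCc2ccccc2)cc1Cl` gives 5000 nM in this assay, and compound 2 `Cc1cc(S(=O)(=O)/N=C(\N)N/N=C/C#Cc2ccccc2)c(SCc2ccccc2C)cc1Cl` gives 19000 nM, so compound 3 stands beyond the scatter above both.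

Compound 4 `C/C(C#Cc1ccccc1)=N\N/C(N)=N/S(=O)(=O)c1cc(C)c(Cl)cc1SCc1cccc2ccccc12` differs from compound 3 in a single place: naphthalen-1-yl in place of 4-methylphenyl on a saturated chain carbon bound to a sulfur. Among the compounds with values here, the only measured step that alters this part of the molecule is a 3.8-fold higher number from compound 1 to compound 2 (0.58 log units; beyond the scatter), where a methyl added to the ring of the benzylsulfanyl group weakened inhibition. Within the data shown here, no measured pair shows what a larger aromatic group does here, and compound 3 differs from compound 2 in two places, so their values only show that compound 3 is weaker.

Because a change at this ring gave a 3.8-fold higher number from compound 1 to compound 2 (0.58 log units; beyond the scatter), a modest further weakening is expected for compound 4, with wide uncertainty in either direction, an expected step of a 1.4-fold higher number from compound 3 to compound 4 (0.13 log units; within the scatter). Compound 4 is thus estimated at 150000 nM, in a range from 35000 nM to 500000 nM.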

Compound 4, half-maximal inhibitory concentration: 125000 nM
Compound 4: middle estimate off by 1.2-fold (0.08 log units), on the high side; measured number inside the range.
By their numbers in this assay, from the lowest: compound 1; then compound 2; then compounds 3 and 4 (each within the scatter of the next).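

In this assay, naphthalen-1-yl in place of 4-methylphenyl on a saturated chain carbon bound to a sulfur gives a 1.1-fold higher number from compound 3 to compound 4 (0.06 log units; within the scatter). The earlier step at this part of the molecule, a 3.8-fold higher number from compound 1 to compound 2 (0.58 log units; beyond the scatter), lay beyond the scatter, whereas this exchange, with 10 heavy atoms entering for 7 and two six-membered aromatic rings for one, leaves the number within it. Nothing measured here accounts for this outcome.

The compounds shown leave open whether an amine or a carboxylic acid in place of naphthalen-1-yl, or a longer chain from the sulfur, would move the number at this position. They also leave open whether naphthalen-1-yl on the core of compound 1 would give a number as close to that of its 4-methylphenyl counterpart.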